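Cyclopropylmethoxy in place of ethoxy on an antagonist acid

This account rests on a few compounds, and the source may have more. Where it says the series, first, only, none or still open, it means among the compounds named here.

Measured compounds:
Compound 1, `CCOc1cc2[nH]c(Cc3nn(CC(=O)N4CCOCC4)c(=O)c4ccccc34)nc2cc1Cl`: 10 nM
Compound 2, `CCOc1cc2[nH]c(Cc3nn(CC(=O)O)c(=O)c4ccccc34)nc2cc1Cl`: 17 nM
Compound 3, `C[C@H](C(=O)O)c1nn(Cc2cn3cc(OCC4CC4)c(Cl)cc3n2)c2ccccc2c1=O`: 3.2 nM

Compound 2 sits at the high end of these three numbers in a functional assay on CHO cells for antagonist activity at sphingosine 1-phosphate receptor 2 (Homo sapiens), read by calcium flux; a higher number here means a weaker inhibitor, a lower number a stronger inhibitor. Among the measured compounds shown here, its nearest neighbour is compound 1, and the step of a 1.7-fold higher number from compound 1 to compound 2 (0.23 log units; within the scatter) is the only one between compounds that differ in a single place. Compound 3, built on a different core and with its acid placed differently, gives 3.2 nM, a lower number than compound 2 by more than the scatter.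

Compound 4, `O=C(O)Cn1nc(Cc2nc3cc(Cl)c(OCC4CC4)cc3[nH]2)c2ccccc2c1=O`, is compound 2 with one change: cyclopropyl in place of methyl on a saturated chain carbon bound to an oxygen on an aromatic ring. For the measured compounds named here, no measured step isolates this change. The step from compound 1 to compound 2 concerns the carbonyl end of the molecule and says nothing about the alkoxy group. Compound 3 does carry the cyclopropylmethoxy group and gives the lowest number of the three, but it also differs from compound 2 elsewhere, so its value cannot be credited to the alkoxy group alone.

Compound 4 is therefore expected to land near compound 2, perhaps somewhat lower, with a 1.9-fold lower number from compound 2 to compound 4 (0.28 log units; within the scatter) as the estimated step. The estimate for compound 4 in this assay is 9 nM, with a range from 3 nM to 30 nM.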

Compound 4, half-maximal inhibitory concentration in the sphingosine 1-phosphate receptor 2 assay: 8.8 nM
Estimate against measurement, compound 4: 1.0-fold (0.01 log units) above; low and high end bracket the measured number.
By their numbers in the sphingosine 1-phosphate receptor 2 assay, from the lowest: compound 3; then compounds 4, 1 and 2 (each within the scatter of the next).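

Among the compounds shown here, this is the first step here that isolates the group on the oxygen: in the sphingosine 1-phosphate receptor 2 assay the change from ethoxy to cyclopropylmethoxy gives (a 1.9-fold lower number from compound 2 to compound 4 (0.29 log units; within the scatter)). With the shared core and the carboxylic acid held fixed, the two compounds cannot be told apart in this read-out, so this place accepts the cyclopropyl group in place of methyl without a measurable difference in antagonist activity. The same change does register in a physicochemical assay for solubility, measured as thermodynamic solubility, at pH 7.4 (a higher number here means a more soluble compound, a lower number a less soluble compound), where the difference is modest but real: (the measured solubility of compound 2, 917 ug/mL, and of compound 4, 395 ug/mL, a 2.3-fold lower number (0.37 log units; beyond the scatter)). In the physicochemical assay compound 2 gives 917 ug/mL and compound 4 gives 395 ug/mL.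

The compounds shown stop at ethoxy and cyclopropylmethoxy at this place, so it remains open whether a longer chain such as butoxy, or an alkoxy chain carrying an amine, would keep the antagonist number and the solubility where they stand. For the compounds shown here, it is also open whether the same change would behave alike with the morpholin-4-yl group of compound 1 on the carbonyl carbon, since this one pair of carboxylic acids is the only place where the change can be read.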